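This account rests on a few compounds, and the source may have more. Where it says the series, first, only, none or still open, it means among the compounds named here.

Compound 3 `CC1=CC[C@H](C(C)(C)NC(=S)N/N=C/c2ccccc2O)CC1` carries a 2-hydroxyphenyl on the carbon with a double bond to nitrogen, and in an ADME assay on Vero cells (Chlorocebus sabaeus) for inhibition, read by sulforhodamine B assay, with a stated time of 48 h (on this read-out lower numbers stand for stronger inhibition of growth and higher numbers for weaker inhibition of growth), compound 3 gives 11200 nM. Among the three measured compounds it is the only one that yields a number at all. Compound 1 `CC1=CC[C@H](C(C)(C)NC(=S)N/N=C/c2ccccc2)CC1`, with an unsubstituted phenyl, reaches only a limit of the assay in this assay, where compound 1 gives > 100000 nM. Compound 2 `CC1=CC[C@H](C(C)(C)NC(=S)N/N=C/c2ccc(O)cc2)CC1`, with a 4-hydroxyphenyl, likewise stops at a limit in this assay, where compound 2 gives > 100000 nM. Both of these sit at the limit of > 100000 nM in this assay, at which 2 of the 3 values shown sit. The steps leading to compound 3 are an at least 8.9-fold lower number from compound 1 to compound 3 (0.95 log units; beyond the scatter) and an at least 8.9-fold lower number from compound 2 to compound 3 (0.95 log units; beyond the scatter), whereas a step that the two limits leave unreadable from compound 1 to compound 2 has no readable size, as both of its values are limits.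

Compound 4 `CC1=CC[C@H](C(C)(C)NC(=S)N/N=C/c2ccc(F)cc2)CC1` differs from compound 3 by 4-fluorophenyl in place of 2-hydroxyphenyl on a carbon with a double bond to nitrogen. It thus resembles compound 1 in lacking the hydroxy and compound 2 in carrying a 4-substituted phenyl, and neither of those gave a number in this assay. Compound 4 is therefore expected to move back toward the limit, with an 8.0-fold higher number from compound 3 to compound 4 (0.91 log units; beyond the scatter) as a higher number. The estimate for compound 4 in this assay is 90000 nM, within a range from 25000 nM to 300000 nM, and most likely only a limit will be reported.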

Compound 4, concentration for total growth inhibition: > 100000 nM
Compound 4 ended at the assay's limit; the forecaster's own chance of this, stated with the estimate: 70%; middle value at least 1.1-fold (0.04 log units) from the limit.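

Within this assay, exchanging the 2-hydroxyphenyl on the carbon with a double bond to nitrogen for 4-fluorophenyl gives an at least 8.9-fold higher number from compound 3 to compound 4 (0.95 log units; beyond the scatter), so this second comparison with compound 3 shows that a fluoro-bearing ring also fails to keep a measurable value. Compound 4 joins compound 1 and compound 2, so among the compounds shown the plain phenyl, the 4-hydroxyphenyl and the 4-fluorophenyl all end at the limit, and only the 2-hydroxyphenyl of compound 3 gives a number: the limit of > 100000 nM in this assay, at which 3 of the 4 values shown sit. The steps among compound 1, compound 2 and compound 4 cannot be read, since both ends of each are limits.

The compounds shown leave open whether an amine or a methoxy on the ring in place of the hydroxy of compound 3 would also give a number, and whether the hydroxy of compound 3 or the place it occupies is what counts. They also leave open how far compound 1, compound 2 and compound 4 lie from one another, since their true values are hidden behind the same limit.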